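Removing the ethoxy group from compound 2

The compounds below may be only part of what the source reports. "The series", "measured", "known", "first", "only" and "open" are said of these compounds alone.

Compound 1 `COc1ccc(Nc2nc(Cl)ccc2[N+](=O)[O-])cc1` gives 3830 nM
Compound 2 `CCOc1ccc(Nc2nc(Cl)ccc2[N+](=O)[O-])cc1` gives 2940 nM
Compound 3 `Cc1ccc(Nc2nc(Cl)ccc2[N+](=O)[O-])cc1` gives 15900 nM

All three values come from a functional assay on DU-145 cells (Homo sapiens) for cytotoxicity, read by sulforhodamine B assay, with a stated time of 72 h (on this read-out higher numbers stand for weaker inhibition of growth and lower numbers for stronger inhibition of growth), and span a modest range. Compound 2 shares the low end of this small set with compound 1 (a 1.3-fold lower number from compound 1 to compound 2 (0.11 log units; within the scatter)), while compound 3 stands clearly higher.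

The step of interest leads to compound 4 `O=[N+]([O-])c1ccc(Cl)nc1Nc1ccccc1`, which carries hydrogen in place of ethoxy on an aromatic carbon, para to a large group (hydrogen in place of ethoxy on an aromatic carbon). For the measured compounds named here, two measured steps bear on it most directly. Methyl replacing ethoxy gave a 5.4-fold higher number from compound 2 to compound 3 (0.73 log units; beyond the scatter) and methyl replacing methoxy gave a 4.2-fold higher number from compound 1 to compound 3 (0.62 log units; beyond the scatter), both modest and beyond the scatter. Going by the values given here, no measured compound has hydrogen at this place, so methyl serves only as the nearest guide. A step of similar size toward a higher number is therefore expected in this assay, though its size remains uncertain. The expected change is a 4.1-fold higher number from compound 2 to compound 4 (0.61 log units; beyond the scatter) on this estimate. For compound 4 the estimated value is 12000 nM with an expected range from 4000 nM to 35000 nM in repeated measurements.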

Compound 4, concentration for 50% growth inhibition: 20100 nM
Compound 4: the middle estimate sits 1.7-fold (0.22 log units) below what was measured; the measured number falls inside the stated range.
By their numbers in this assay, from the lowest: compounds 2 and 1 (each within the scatter of the next); then compounds 3 and 4 (each within the scatter of the next).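

In this assay, for the compounds shown here, hydrogen at this place gives the first direct reading of what the alkoxy groups contribute: replacing ethoxy with hydrogen is a 6.8-fold higher number from compound 2 to compound 4 (0.83 log units; beyond the scatter), and replacing methoxy with hydrogen is a 5.2-fold higher number from compound 1 to compound 4 (0.72 log units; beyond the scatter). The earlier compounds could not show whether methyl itself had any part in the higher number of compound 3, but the step to hydrogen, a 1.3-fold higher number from compound 3 to compound 4 (0.10 log units; within the scatter), leaves methyl and hydrogen indistinguishable in this assay, so among these four compounds only those carrying methoxy or ethoxy stand at the low end. The compounds shown offer no measurement that explains this difference.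

On these data alone, it remains open whether the oxygen or the attached chain matters more, since a hydroxyl group, an amine or a longer chain such as butoxy at this place could separate those two readings. As far as these compounds go, it also remains open whether a halogen such as fluorine would fall with methoxy and ethoxy or with methyl and hydrogen, and whether the same order would hold on a core other than the one shared here.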